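A few compounds are considered here, and "the series" means these few. Any claim that something is new, unique, unknown or untested is made for them only; others in the source may bear on it.

Among the compounds with values here, compound 2 `CC(C)(C)c1cnc(CCc2ccc(-c3ccccc3C(=O)O)cc2)[nH]1` gives the highest of the two numbers measured so far in an in vitro functional assay on cells for agonist activity at Bombesin receptor subtype-3 (Homo sapiens), read by luminescence and calcium flux (on this read-out higher numbers stand for an effect only at larger amounts of compound and lower numbers for an effect already at smaller amounts), at 4330 nM. Its nearest neighbour is compound 1 `CC(C)(C)Cc1cnc(CCc2ccc(-c3ccccc3C(=O)O)cc2)[nH]1`, which in this assay gives 106 nM. Within the data shown here, the one measured step, a 41-fold higher number from compound 1 to compound 2 (1.61 log units; beyond the scatter), shows that shortening the group on that carbon of the core from neopentyl to tert-butyl cost a large amount of activity. Compound 3 `O=C(O)c1ccccc1-c1ccc(CCc2ncc(Cc3cccc(Cl)c3)[nH]2)cc1` has not yet been measured in this assay; its difference from compound 2 is this: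
3-chlorobenzyl in place of tert-butyl on an aromatic carbon
Among the measured compounds shown here, the only step that bears on this change is the one from compound 1 to compound 2, and it went the opposite way: it removed bulk, whereas here a 3-chlorobenzyl group, larger than tert-butyl by the count given, is restored to the same carbon. A large step downward is therefore anticipated, broadly mirroring that loss. Compound 3 is expected to give about 80 nM in this assay, within a range of 15 nM to 500 nM, an estimated step of a 54-fold lower number from compound 2 to compound 3 (1.73 log units; beyond the scatter).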

Compound 3, half-maximal effective concentration: 825 nM
Compound 3: the middle estimate sits 10-fold (1.01 log units) below what was measured; the whole stated range lies below it.
By their numbers in this assay, from the lowest: compound 1; then compound 3; then compound 2.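

In this assay, a group carrying a six-membered aromatic ring is tolerated on this carbon, and moving from tert-butyl to 3-chlorobenzyl gives a 5.2-fold lower number from compound 2 to compound 3 (0.72 log units; beyond the scatter), so part of the activity lost on shortening neopentyl returns. That recovery is incomplete, as the change at the saturated chain carbon, 3-chlorophenyl in place of tert-butyl, gives a 7.8-fold higher number from compound 1 to compound 3 (0.89 log units; beyond the scatter), so across these three compounds the number does not simply fall as the group grows, with compound 3 carrying the 3-chlorobenzyl group yet not reaching compound 1. Nothing available accounts for this order.

The compounds shown leave open what the chlorine contributes, since an unsubstituted benzyl group does not appear among them. They also leave open whether a longer chain between the ring and this carbon, or an amine on that ring, would bring the number closer to that of compound 1.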